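The compounds below may be only part of what the source reports. "The series", "measured", "known", "first", "only" and "open" are said of these compounds alone.

Measured so far:
- compound 1, `COc1ccc(N2CCN(C(=S)SCc3ccc(C(=O)Nc4ccccc4N)cc3)CC2)cc1`: 25.3%
- compound 2, `Nc1ccccc1NC(=O)c1ccc(CSC(=S)N2CCCc3ccccc32)cc1`: 38.5%

Both compounds were tested in a functional assay on MGC-803 cells (Homo sapiens) for antiproliferative activity, read by CCK-8 assay, with a stated time of 72 h, tested at 2 uM; on this read-out lower numbers stand for a weaker effect and higher numbers for a stronger effect at the one concentration tested. In this assay compound 1 gives 25.3%, and compound 2 gives 38.5%. Compound 2 therefore holds the higher of the two numbers, and its distance from compound 1 lies beyond the usual scatter of repeated measurements, so compound 2 is the stronger of the pair on this read-out.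

The next compound to consider is compound 3, `CC1CCN(C(=S)SCc2ccc(C(=O)Nc3ccccc3N)cc2)CC1`. It differs from compound 2 in one place: 4-methylpiperidin-1-yl in place of 1,2,3,4-tetrahydroquinolin-1-yl on a thiocarbonyl carbon. The shared core, with its aminophenyl amide and the sulfur-linked thiocarbonyl, stays untouched.

Within the data shown here, no measured pair shows what this kind of swap does in this assay, so only an expectation can be offered. Compound 1 also carries a saturated nitrogen ring on the thiocarbonyl carbon and gives 25.3%, and on that basis the step from compound 2 to compound 3 is expected to be downward by a number 10.5 percentage points lower from compound 2 to compound 3 (beyond the scatter), roughly at the edge of the scatter. Compound 3 is thus estimated to reach 28%, with a likely range from 15% to 42%.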

Compound 3, a percentage reported as inhibition, at one concentration (the size of the read-out at that concentration, not a potency): 28.1%
Compound 3: middle estimate off by 0.1 percentage points, on the low side; low and high end bracket the measured number.
By their numbers in this assay, from the lowest: compounds 1 and 3 (each within the scatter of the next); then compound 2.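

In this assay, among these compounds, this is the first one-place change that can be read at this position on a thiocarbonyl carbon, and replacing 1,2,3,4-tetrahydroquinolin-1-yl with 4-methylpiperidin-1-yl gives a number 10.4 percentage points lower from compound 2 to compound 3 (beyond the scatter). So the group on this carbon does influence the read-out, and in this pair the higher number goes with the group that carries a six-membered aromatic ring of carbon only. The swap also changes more than that ring, since the entering group brings a methyl and has fewer heavy atoms, and no measurement here explains the step or assigns it to any one of these differences.

The compounds shown leave open whether plain piperidin-1-yl, without the methyl, or an open-chain diethylamino group at the same place would give a number closer to that of compound 2 or compound 3. On these data alone, each number also comes from a single concentration, so it remains open whether the same step would appear in a full potency measurement.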